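The compounds below may be only part of what the source reports. "The series", "measured", "known", "first", "only" and "open" are said of these compounds alone.

Of the compounds shown here, two built on a shared core have been tested in an assay on HEK293 cells for displacement of a labelled ligand from NPC1-like intracellular cholesterol transporter 1 (Homo sapiens); on this read-out lower numbers stand for stronger inhibition and higher numbers for weaker inhibition. Compound 1 `CC(C)(C)OC(=O)NC1CCN(C(=O)CN2CN(c3ccccc3)C3(CCN(C(=O)c4ccc(C(C)(C)C)cc4)CC3)C2=O)CC1` carries a (tert-butoxycarbonyl)amino group on a saturated ring carbon, and in this assay compound 1 gives 8300 nM. Compound 2 `CC(C)(C)OC(=O)NCCCCNC(=O)CN1CN(c2ccccc2)C2(CCN(C(=O)c3ccc(C4CCCCC4)cc3)CC2)C1=O` gives 4600 nM in this assay. Compound 1 stands at the higher of the two numbers, yet its difference from compound 2 lies within the usual scatter, so no real order can be read from the pair.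

Compound 3 `CC(C)(C)c1ccc(C(=O)N2CCC3(CC2)C(=O)N(CC(=O)N2CCC(O)CC2)CN3c2ccccc2)cc1` is compound 1 with a single change: hydroxy in place of (tert-butoxycarbonyl)amino on a saturated ring carbon

For the measured compounds named here, no measured pair shows what this change does, so the expectation rests on the weak starting point alone. The step of a 1.4-fold higher number from compound 1 to compound 3 (0.16 log units; within the scatter) is expected to lean toward a higher number, a mild weakening, though it could also stay within the scatter. Compound 3 is therefore estimated at 12000 nM, with a likely range from 3500 nM to 40000 nM.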

Compound 3, half-maximal inhibitory concentration: 4700 nM
The estimate for compound 3 lay 2.6-fold (0.41 log units) above the measured number; measured number inside the range.
By their numbers in this assay, from the lowest: compounds 2, 3 and 1 (each within the scatter of the next).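

On this saturated ring carbon, hydroxy in place of (tert-butoxycarbonyl)amino gives a 1.8-fold lower number from compound 1 to compound 3 (0.25 log units; within the scatter) in this assay. The position therefore goes from a group of 8 heavy atoms to one of 1 heavy atom with no difference that can be told from the scatter, so in this pair the larger group is not needed to keep the number where it stands. No measurement at hand offers a reason for this result.

Still open, on these data alone, is whether any group on this ring carbon can move the number beyond the scatter in either direction, and a simple amine or a carboxylic acid there would help to show this. A longer chain ending in hydroxy would show whether the reach of the group matters at this position.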